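The source may hold more compounds than are shown below. What is called first, only, known or untested is meant among the compounds shown, and "the series" means these compounds.

Measured so far in a physicochemical assay for lipophilicity, read by HPLC, with a stated time of 90 min, tested at 100 uM; a lower number here means a more polar compound, a higher number a more lipophilic compound:
compound 1 `CC(C)C(=O)N1CCC(NC(=O)Nc2ccc(C(F)(F)F)c(F)c2)CC1`, 4.4
compound 2 `CC(C)C(=O)N1CCC(NC(=O)Nc2ccc(OC(F)(F)F)c(F)c2)CC1`, 4.73
compound 3 `O=C(Nc1ccc(C(F)(F)F)c(F)c1)NC1CCN(C(=O)C2(C(F)(F)F)CC2)CC1`, 5.52

Compound 2 stands second highest of the three. Its nearest neighbour is compound 1, separated by a number 0.33 log units higher from compound 1 to compound 2 (beyond the scatter), while compound 3 gives the highest number of the set. Compound 4 `CCC(=O)N1CCC(NC(=O)Nc2ccc(OC(F)(F)F)c(F)c2)CC1` differs from compound 2 in one place: hydrogen in place of methyl on a saturated chain carbon bound to a carbonyl carbon and a saturated chain carbon. For the measured compounds named here, no measured step removes a methyl at this position. Going by the values given here, the only change on the carbonyl substituent is a number 1.12 log units higher from compound 1 to compound 3 (beyond the scatter), a large rise on going to 1-(trifluoromethyl)cyclopropyl; the aryl change a number 0.33 log units higher from compound 1 to compound 2 (beyond the scatter) does not bear on this position. Removing the methyl is expected to lower this assay modestly, by a number 0.40 log units lower from compound 2 to compound 4 (beyond the scatter). Compound 4 is therefore estimated at 4.33, with a range of 3.95 to 4.7.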

Compound 4, partition coefficient: 4
Compound 4: the middle estimate sits 0.33 log units above what was measured, within the range that was stated.
By their numbers in this assay, from the lowest: compound 4; then compound 1; then compound 2; then compound 3.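

Isopropyl to ethyl is the one listed change that takes a carbon out of the carbonyl substituent, and in this assay it gives a number 0.73 log units lower from compound 2 to compound 4 (beyond the scatter). For the compounds shown here, this position therefore moves the number downward as well as upward, the only earlier step here being a number 1.12 log units higher from compound 1 to compound 3 (beyond the scatter), made with trifluoromethyl rather than trifluoromethoxy on the aromatic carbon. No supporting data explain the size of the new step.

As far as these compounds go, whether the same change gives a similar step with trifluoromethyl on the aromatic carbon remains open. So does the outcome with a longer chain or an amine on the carbonyl carbon.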